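Triazole substituent swap in a furanone series

This account rests on a few compounds, and the source may have more. Where it says the series, first, only, none or still open, it means among the compounds named here.

Measured so far:
Compound 3 `CC(C)(C)c1cn(C[C@H](O)[C@H]2OC(=O)C(OCc3ccccc3)=C2OCc2ccccc2)nn1` gives 34000 nM in a functional assay on A549 cells (Homo sapiens) for antiproliferative activity, read by MTT assay, with a stated time of 72 h; a higher number here means a weaker inhibitor, a lower number a stronger inhibitor.
Compound 1 `O=C1O/C(=C\Cn2cc(-c3cc(F)cc(F)c3)nn2)C(OCc2ccccc2)=C1OCc1ccccc1` reaches only the limit > 100000 nM in this assay.
Compound 2 `CC(C)(C)OC(=O)N1CCN(C(=S)SCc2cn(C[C@H](O)[C@H]3OC(=O)C(OCc4ccccc4)=C3OCc3ccccc3)nn2)CC1` likewise reaches only the limit > 100000 nM in this assay.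

For the measured compounds named here, compound 3 thus holds the only number in the set; the other two sit at the limit of > 100000 nM in this assay, at which 2 of the 3 values shown sit, so no step between measured compounds can be stated, and compound 3 cannot be ranked against them beyond saying that a number was obtained for it.

Compound 4 `COc1ccc(-c2cn(C[C@H](O)[C@H]3OC(=O)C(OCc4ccccc4)=C3OCc3ccccc3)nn2)cc1` differs from compound 3 by 4-methoxyphenyl in place of tert-butyl on an aromatic carbon. Going by the values given here, no measured pair in this set carries that change, so the expected size of the step in this assay rests on nothing firmer than the hydroxyl-bearing linker that compound 3 and compound 4 share. A step within the scatter, or a modest one in either direction, is expected; the estimated step of a 1.4-fold lower number from compound 3 to compound 4 (0.13 log units; within the scatter) is set near zero. Compound 4 is expected at 25000 nM, with a range from 6000 nM to 100000 nM, and some chance that only a limit is returned.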

Compound 4, half-maximal inhibitory concentration: 28300 nM
Estimate against measurement, compound 4: 1.1-fold (0.05 log units) below, and the stated range covers the measured number.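

In this assay, for the compounds shown here, the step at this aromatic carbon of the five-membered ring is the first that can be read: a 1.2-fold lower number from compound 3 to compound 4 (0.08 log units; within the scatter). A 4-methoxyphenyl, with its six-membered aromatic ring and hydrogen-bond acceptor, and a tert-butyl, with neither, therefore give values within the scatter of each other on the shared hydroxyl-bearing linker. The position thus takes either group without a readable difference, though this rests on a single pair.

Steps to compound 1 and compound 2 cannot be read, as each of these compounds returns only a limit: the limit of > 100000 nM in this assay, at which 2 of the 4 values shown sit.

On these data alone, whether an amine or a carboxylic acid on this same aromatic carbon would give a step beyond the scatter remains open.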